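The source may hold more compounds than are shown below. What is called first, only, known or untested is meant among the compounds shown, and "the series" means these compounds.

In an assay on cells for positive allosteric modulation of Cystic fibrosis transmembrane conductance regulator variant F508del (Homo sapiens), with stated times of 10 min and 7 s, in the presence of a further agent that is not named here (a higher number here means that more compound is needed for the effect, a lower number that less compound is needed), compound 1 `Cc1ccc(C(=O)Nc2sc3c(c2C(N)=O)CCCC3)s1` gives 652 nM. Compound 2 `CC1(C)Cc2c(sc(NC(=O)C3CNC(=O)C3)c2C(N)=O)C(C)(C)O1` gives no number but only a limit, > 10000 nM, standing at the limit of > 10000 nM in this assay, at which 1 of the 3 values shown sits. Going by the values given here, compound 3 `Cc1cn[nH]c1C(=O)Nc1sc2c(c1C(N)=O)CC(C)(C)OC2(C)C`, carrying a 4-methyl-1H-pyrazol-5-yl on the carbonyl carbon, gives 2 nM in this assay, and the step of an at least 5000-fold lower number from compound 2 to compound 3 (3.69 log units; beyond the scatter) is the one measured change that bears on the question here. Compound 4 `Cc1n[nH]c(C(=O)Nc2sc3c(c2C(N)=O)CC(C)(C)OC3(C)C)c1Cl` differs from compound 2 by a group of 7 heavy atoms (4 carbon, 2 nitrogen, 1 chlorine; one five-membered aromatic ring with 2 hetero atoms) in place of a group of 6 heavy atoms (4 carbon, 1 nitrogen, 1 oxygen; one five-membered non-aromatic ring with 1 hetero atom), on a carbonyl carbon. This change likewise puts a five-membered aromatic ring with 2 hetero atoms in place of the 5-oxopyrrolidin-3-yl, so a large step toward a lower number in this assay is expected, and compound 4 is expected to show an at least 2000-fold lower number from compound 2 to compound 4 (3.30 log units; beyond the scatter). Compound 4 is thus estimated at 5 nM in this assay, between 1 nM and 40 nM.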

Compound 4, half-maximal effective concentration: 11 nM
For compound 4 the middle estimate is 2.2-fold (0.34 log units) below the measured one; the range from low to high includes it.
By their numbers in this assay, from the lowest: compound 3; then compound 4; then compound 1. At a limit, above all of these: compound 2.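

Going by these compounds alone, a second five-membered aromatic ring with 2 hetero atoms on the carbonyl carbon also gives a large change in this assay, so the gain over 5-oxopyrrolidin-3-yl is not tied to the single group in compound 3: an at least 900-fold lower number from compound 2 to compound 4 (2.95 log units; beyond the scatter). The figure for compound 2 is a limit, not a number: the limit of > 10000 nM in this assay, at which 1 of the 4 values shown sits. Between the two aromatic groups, the one carrying chlorine gives a smaller, modest change: a 5.5-fold higher number from compound 3 to compound 4 (0.74 log units; beyond the scatter). Still open, from the compounds shown here alone, is which of the differences between those two groups produces that change, and how this aromatic ring would behave carrying an amine or a carboxylic acid.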